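A Fluoro-to-Cyano Swap Next to the Ring Nitrogen

This account rests on a few compounds, and the source may have more. Where it says the series, first, only, none or still open, it means among the compounds named here.

Two compounds have been measured in an in vitro functional assay on HEK293-A cells for agonist activity at metabotropic glutamate receptor 5 (Rattus norvegicus), read by ELISA; a lower number here means a stronger inhibitor, a higher number a weaker inhibitor:
- compound 1 `N#Cc1cc(F)cc(C#Cc2cccc(F)n2)c1` gives 80 nM
- compound 2 `N#Cc1cccc(C#Cc2cccc(F)n2)c1` gives 210 nM

Compound 1 holds the lowest of these two numbers, and its closest neighbour, compound 2, sits at a clearly higher one. Going by the values given here, the single measured step, a 2.6-fold higher number from compound 1 to compound 2 (0.42 log units; beyond the scatter), shows that removing the fluoro from the ring that carries the nitrile costs a modest but real amount of activity.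

Compound 3 `N#Cc1cc(F)cc(C#Cc2cccc(C#N)n2)c1` is not yet measured. It differs from compound 1 by cyano in place of fluoro on an aromatic carbon. This change sits on the other ring, on an aromatic carbon of a six-membered aromatic ring with one nitrogen, next to the ring nitrogen, so the measured step does not speak to it directly. Only the fluoro-removal step is available, and it concerns a different ring and a different kind of swap, so the expectation rests on compound 1 alone. No step beyond the usual scatter is expected in this assay, in either direction, though the range is kept wide. The estimate for compound 3 is 100 nM, between 30 nM and 350 nM, which corresponds to an expected step of a 1.3-fold higher number from compound 1 to compound 3 (0.10 log units; within the scatter).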

Compound 3, half-maximal inhibitory concentration: 9 nM
The estimate for compound 3 lay 11-fold (1.05 log units) above the measured number, and the stated range ends above it.
By their numbers in this assay, from the lowest: compound 3; then compound 1; then compound 2.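

Going by these compounds alone, until this result, the only change with a measured effect lay on the ring that carries the nitrile. Compound 3 shows that the position next to the ring nitrogen, on the other ring, also matters in this assay: cyano in place of fluoro there gives an 8.9-fold lower number from compound 1 to compound 3 (0.95 log units; beyond the scatter). Set beside a 2.6-fold higher number from compound 1 to compound 2 (0.42 log units; beyond the scatter), this is the larger of the two changes measured from compound 1, and it shows that a fluoro at this position can be exchanged with a clear gain rather than a loss. The swap adds one heavy atom and one hydrogen-bond acceptor by count, but nothing available here links either difference to the lower number.

Cyano is the only replacement for fluoro shown at this position, so it stays open whether a chloro, a methyl, a methoxy or an amine there would give a similar number, or whether the gain is particular to cyano. Also open, on these data alone, is whether the same swap would give a step of similar size on the core of compound 2, which has no fluoro on the ring carrying the nitrile.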